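This account rests on a few compounds, and the source may have more. Where it says the series, first, only, none or still open, it means among the compounds named here.

Compound 1, with the structure `Nc1cccc(CNC(=O)Nc2ccc(-c3cn[nH]c3)cc2)c1`, gives 3 nM; 3 nM (2 entries) in an assay on isolated protein for inhibition of Rho-associated protein kinase 2 (Homo sapiens), read by HTRF, with a stated time of 4 h (a lower number here means a stronger inhibitor, a higher number a weaker inhibitor), where a methoxy takes the place of the amino group and a dimethylamino is added to the central ring in compound 2, whose structure is `COc1cccc(CNC(=O)Nc2ccc(-c3cn[nH]c3)cc2N(C)C)c1`. For compound 2 this assay reports only a limit, < 1 nM, and not a number. Compound 3, with the structure `COc1cccc(CNC(=O)Nc2ccc(-c3cn[nH]c3)cc2Cl)c1`, carries a chloro where compound 2 carries the dimethylamino. For compound 3 this assay again reports only a limit, < 1 nM. Compound 3 therefore stands at the floor of what this assay can read, sharing (the limit of < 1 nM in this assay, at which 2 of the 3 values shown sit), and the step that the two limits leave unreadable from compound 2 to compound 3 cannot be sized.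

Compound 4, with the structure `COc1cccc(CNC(=O)Nc2ccc(-c3cn[nH]c3)cc2F)c1`, differs from compound 3 by fluoro in place of chloro on an aromatic carbon: a fluoro in place of a chloro. Within the data shown here, no measured step swaps one halogen for another here, so the only bearing evidence is that compound 3 itself already lies at the limit. A step of no size beyond the scatter is expected in this assay, so that a step that the limit leaves unreadable from compound 3 to compound 4 is estimated. Compound 4 is therefore expected to give about 0.9 nM, within a range from 0.3 nM to 3 nM, with a fair chance that this assay again reports only a limit.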

Compound 4, half-maximal inhibitory concentration: < 1 nM
Compound 4: only a limit was reported; the forecaster's own chance of this, stated with the estimate: 50%; the middle value is on the limit's open side.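

In this assay compound 4 gives < 1 nM, which is a limit and not a number. The steps among compound 2, compound 3 and compound 4 therefore cannot be read. The compounds shown leave open how the dimethylamino, chloro and fluoro compounds truly compare, because their values all stop at the same floor: the limit of < 1 nM in this assay, at which 3 of the 4 values shown sit.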